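The compounds below may be only part of what the source reports. "The series", "measured", "known", "first", "only" and "open" are said of these compounds alone.

Measured compounds:
compound 1 `COc1cccc(Cc2nn(C[C@H]3CCCN3C)c(=O)c3ccccc23)c1` — > 1990 nM
compound 2 `CN1CCCCC(n2nc(Cc3ccc(Cl)cc3)c3ccccc3c2=O)C1` — 158 nM

In an assay for binding affinity to Alpha-1B adrenergic receptor (Homo sapiens) (a higher number here means a weaker inhibitor, a lower number a stronger inhibitor), compound 1 returns only a limit of the assay, not a number: > 1990 nM. So where compound 1 stands is known only as the limit of > 1990 nM in this assay, at which 1 of the 2 values shown sits, with no value to place it more closely. Compound 2 `CN1CCCCC(n2nc(Cc3ccc(Cl)cc3)c3ccccc3c2=O)C1` does give a number in this assay, 158 nM, but it differs from compound 1 in more than one place, so the two values are simply shown side by side and no single step is drawn between them.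

Compound 3 `COc1ccc(Cc2nn(C[C@H]3CCCN3C)c(=O)c3ccccc23)cc1` is not yet measured. It differs from compound 1 as follows: 4-methoxyphenyl in place of 3-methoxyphenyl on a saturated chain carbon bound to an aromatic carbon. Going by the values given here, no measured step of this kind is available, so no step beyond the usual scatter is expected in either direction for this assay; the estimate for compound 3 is therefore placed near the limit of compound 1.

Compound 3 is expected to give about 3000 nM in this assay, within roughly 800 nM to 12000 nM. The step this estimate implies is a step that the limit leaves unreadable from compound 1 to compound 3, and a further limit readout rather than a number is considered quite likely.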

Compound 3, inhibition constant: 158 nM
For compound 3 the middle estimate is 19-fold (1.28 log units) above the measured one; the whole stated range lies above it.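

In this assay, 4-methoxyphenyl in place of 3-methoxyphenyl on a saturated chain carbon bound to an aromatic carbon gives an at least 12-fold lower number from compound 1 to compound 3 (1.10 log units; beyond the scatter). Going by these compounds alone, the two compounds have the same atoms, joined differently, so this is the first sign that the readout at this position depends on where the methoxy group sits on the phenyl ring, which compound 1 alone could not show. The value of compound 1 is a limit of the assay, so the step has a lower bound but no full size: the limit of > 1990 nM in this assay, at which 1 of the 3 values shown sits.

From the compounds shown here alone, it remains open whether the methoxy group itself matters or only its placement, as a plain phenyl, a 4-hydroxyphenyl or a 4-fluorophenyl at the same place would help to tell. Going by these compounds, it also remains open whether the step carries over to other adrenergic receptors.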